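This account rests on a few compounds, and the source may have more. Where it says the series, first, only, none or still open, it means among the compounds named here.

Compound 1 `CNC(=O)c1cncc(NS(=O)(=O)c2cc(Cl)ccc2OC)c1` is one of two measured members of this small set. In an assay on isolated protein for inhibition of alkaline phosphatase, tissue-nonspecific isozyme (Homo sapiens) (a lower number here means a stronger inhibitor, a higher number a weaker inhibitor), compound 1 gives > 20000 nM, which is a limit of the assay rather than a measured number. Compound 2 `COc1ccc(OC)c(S(=O)(=O)Nc2cncc(-c3ccncc3)c2)c1` is the other measured member. In this assay compound 2 gives > 20000 nM, again a limit and not a number. Both readings therefore rest at the limit of > 20000 nM in this assay, at which 2 of the 2 values shown sit, so compound 1 stands at the edge of what the assay reports, and no order between compound 1 and compound 2 can be read from the two values.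

Compound 3 `COc1ccc(Cl)cc1S(=O)(=O)Nc1cncc(C(N)=O)c1` has not yet been measured. It differs from compound 1 by hydrogen in place of methyl on an amide-type nitrogen. Among the measured compounds shown here, with no step between measured compounds available, the only guide is that compound 1 itself sits at the limit. For a change this small, the step is expected to lie within the scatter, with no direction beyond it, and the estimated step that the limit leaves unreadable from compound 1 to compound 3 reflects that. Compound 3 is therefore expected to give about 30000 nM, with a range from 10000 nM to 100000 nM, most likely reported again only as a limit.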

Compound 3, half-maximal inhibitory concentration: 105 nM
Compound 3: the middle estimate sits 290-fold (2.46 log units) above what was measured; the whole stated range lies above it.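

The hydrogen in place of methyl on the amide-type nitrogen proves decisive at this position: in this assay the change gives an at least 190-fold lower number from compound 1 to compound 3 (2.27 log units; beyond the scatter), a large step for the loss of one carbon. As far as these compounds go, the true size of the step stays unknown because compound 1 gives only a limit at the edge of what the assay reports: the limit of > 20000 nM in this assay, at which 2 of the 3 values shown sit. The two earlier compounds showed only limits and so said nothing about this position. Compound 3 gives a real number, 105 nM, which shows that the carbamoyl group is compatible with inhibition on this core while the methylcarbamoyl group of compound 1 does not reach a readable value.

From the compounds shown here alone, what a carboxylic acid, a nitrile or a longer chain on the amide nitrogen, such as ethyl, would do at this position remains open. Among the compounds shown here, it is also open whether the same change from methylamino to amino would have so large an effect with a different sulfonyl-bound ring substitution, as only this single pair can be compared.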